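Coumarin-isoxazole ethers: a chloro substituent replaces hydrogen

A few compounds are considered here, and "the series" means these few. Any claim that something is new, unique, unknown or untested is made for them only; others in the source may bear on it.

Compound 1 `O=c1ccc2cc(OCc3cc(-c4ccccc4)no3)ccc2o1` is the parent of this small set; in a functional assay on HCT-116 cells (Homo sapiens) for cytotoxicity, read by MTT assay, with a stated time of 48 h (on this read-out lower numbers stand for stronger inhibition and higher numbers for weaker inhibition), compound 1 stands as "not determined" (no result reported), so no single number places it among its neighbours. Two relatives carry a larger aromatic group at the same position: compound 2 `O=c1ccc2cc(OCc3cc(-c4ccc5ccccc5c4)no3)ccc2o1` gives 55900 nM in this assay, and compound 3 `O=c1ccc2cc(OCc3cc(-c4cccc5ccccc45)no3)ccc2o1` gives 51500 nM in this assay. The two values lie within the usual scatter of each other, so nothing is said about order between them; both mark weak cytotoxicity on this read-out.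

Compound 4 `O=c1ccc2cc(OCc3cc(-c4cccc(Cl)c4)no3)ccc2o1` differs from compound 1 by chloro in place of hydrogen on an aromatic carbon, on an aromatic carbon of a six-membered aromatic ring of carbon only, meta to a large group. Going by the values given here, no measured pair covers this change, and compound 1 itself has no value, so the step is judged from compounds 2 and 3 alone; a small shift, if any, is expected, with no clear direction beyond the scatter. For compound 4 the estimate in this assay is 65000 nM, with a range from 25000 nM to 170000 nM.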

Compound 4, half-maximal inhibitory concentration: 42100 nM
Compound 4: the middle estimate sits 1.5-fold (0.19 log units) above what was measured; the measured number falls inside the stated range.
By their numbers in this assay, from the lowest: compounds 4, 3 and 2 (each within the scatter of the next).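

In this assay, going by these compounds alone, compound 4 gives 42100 nM while compound 1 stands as "not determined" (no result reported) and so no step between compound 1 and compound 4 can be read. The compounds shown leave open what chloro in place of hydrogen does on this read-out. Nothing further is available to explain the value of compound 4.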